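This account rests on a few compounds, and the source may have more. Where it says the series, first, only, none or still open, it means among the compounds named here.

Measured so far in a functional assay on SJSA-1 cells (Homo sapiens) for inhibition, read by CCK-8 assay, with a stated time of 72 h, tested at 1 uM; a higher number here means more inhibition at the concentration tested (going by the name of the read-out), a lower number less inhibition:

compound 1 `COc1ccc(F)cc1N1C(=O)CSC1c1cccc(C(=O)NCCCCc2ccccc2)c1`: 76%
compound 2 `CCN1C(=O)CSC1c1cccc(C(=O)NCCCCc2ccccc2)c1`: 3%
compound 3 `O=C(NCCCCc1ccccc1)c1cccc(C2OCC(=O)N2c2cccc(F)c2)c1`: 32%

Compound 2 gives the lowest of the three numbers in this assay; compound 3 is nearest to it, and compound 1 furthest, both beyond the scatter. For the measured compounds named here, the one measured step that bears on the present question is a number 73 percentage points lower from compound 1 to compound 2 (beyond the scatter), where an aryl group on the ring nitrogen of the shared core is replaced by ethyl.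

Compound 4 `CC(F)(F)c1cccc(N2C(=O)CSC2c2cccc(C(=O)NCCCCc3ccccc3)c2)c1` is not yet measured. Its difference from compound 2 is a group of 10 heavy atoms (8 carbon, 2 fluorine; one six-membered aromatic ring of carbon only) in place of a group of 2 heavy atoms (2 carbon; no ring), on an amide-type nitrogen in a ring. This reverses the direction of the measured step: a group of 10 heavy atoms with one six-membered aromatic ring of carbon only re-enters on the amide-type nitrogen in the five-membered ring with 1 nitrogen and 1 sulfur, in place of the ethyl of compound 2. The aryl group is not the same as that of compound 1, so the size of the gain cannot be read off directly; compound 3, with a different aryl on a different core, gives 32%, which cautions that not every aryl reaches the level of compound 1.

A large upward step is expected in this assay, estimated as a number 52 percentage points higher from compound 2 to compound 4 (beyond the scatter). Compound 4 is therefore expected to give about 55%, with a range of 25% to 85%.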

Compound 4, a percentage reported as inhibition, at one concentration (the size of the read-out at that concentration, not a potency): 68%
The estimate for compound 4 lay 13 percentage points below the measured number; the measured number falls inside the stated range.
By their numbers in this assay, from the lowest: compound 2; then compound 3; then compounds 4 and 1 (each within the scatter of the next).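

In this assay, the amide-type nitrogen in the ring now has a second group with a six-membered aromatic ring of carbon only, and a number 65 percentage points higher from compound 2 to compound 4 (beyond the scatter). The large gap between such a group and ethyl at this position is therefore not tied to the 5-fluoro-2-methoxyphenyl of compound 1, and it holds for two differently substituted aromatic rings on the shared core. The two groups themselves are not separated, at a number 8 percentage points lower from compound 1 to compound 4 (within the scatter), so the methoxy oxygen of compound 1 is not needed to reach this level of inhibition, though no measurement here explains why either group differs from ethyl.

The compounds shown leave open whether the aromatic ring is what matters or whether a saturated ring such as cyclohexyl, a benzyl group or a longer alkyl chain on the same nitrogen would also exceed ethyl. Also open, going by these compounds, is how a nitrogen-containing aromatic ring such as pyridine would compare there, and with readings at a single concentration, compound 1 and compound 4 cannot be ranked by potency.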